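This account rests on a few compounds, and the source may have more. Where it says the series, first, only, none or still open, it means among the compounds named here.

In an ADME assay on L6 cells (Rattus norvegicus) for cytotoxicity (on this read-out lower numbers stand for stronger inhibition and higher numbers for weaker inhibition), compound 1 `C/C=C(/C)C(=O)OC(C)c1cc2c(cc1OC)OC(C)(C)C=C2` gives 139000 nM and compound 2 `COc1cc2c(cc1C(C)OCc1ccccc1)C=CC(C)(C)O2` gives 43900 nM. For the measured compounds named here, compound 2 therefore holds the lower of the only two numbers so far, and the gap between them lies beyond the scatter.

The next compound is compound 3 `COc1cc2c(cc1C(C)OCCc1ccccc1)C=CC(C)(C)O2`, and the change is benzyl in place of phenyl on a saturated chain carbon bound to an oxygen on a saturated carbon. Read one bond further out, this is benzyl to phenethyl, on a saturated chain carbon bound to an oxygen on a saturated carbon.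

Going by the values given here, only one measured step bears on this, and only loosely: a 3.2-fold lower number from compound 1 to compound 2 (0.50 log units; beyond the scatter), a modest step that put benzyl in place of (1-methylprop-1-en-1-yl)carbonyl on an oxygen on a saturated carbon. Among the compounds with values here, no measured pair yet compares benzyl with phenethyl, so the data give no direction for this change. That single step serves only as a rough ceiling on size, and no shift beyond the scatter is expected in this assay.

The expected step is a 1.2-fold lower number from compound 2 to compound 3 (0.06 log units; within the scatter), an estimate that stays within the scatter. For compound 3 the estimated value is 38000 nM, with an expected range of 17000 nM to 85000 nM.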

Compound 3, half-maximal inhibitory concentration: 123000 nM
Estimate against measurement, compound 3: 3.2-fold (0.51 log units) below, outside the stated range (above it).
By their numbers in this assay, from the lowest: compound 2; then compounds 3 and 1 (each within the scatter of the next).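

In this assay, this position does not treat benzyl and phenethyl alike: going one bond further out gives a 2.8-fold higher number from compound 2 to compound 3 (0.45 log units; beyond the scatter), so the benzyl result does not carry over to phenethyl. Phenethyl also shows no separation from the (1-methylprop-1-en-1-yl)carbonyl group on the same oxygen, with a 1.1-fold lower number from compound 1 to compound 3 (0.05 log units; within the scatter), which leaves compound 2 as the only compound set apart from the others, its steps to both lying beyond the scatter. Nothing available accounts for the difference between benzyl and phenethyl at this place.

With only benzyl and phenethyl to compare, the compounds shown cannot tell whether the number keeps rising with a longer chain such as 3-phenylpropyl or whether benzyl is a narrow optimum among the phenyl-bearing chains. They also leave open how this position would respond to an amine or a carboxylic acid on the chain, and whether any such group could take the number below that of compound 2 or would stay level with compound 1 and compound 3.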